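The source may report more compounds than this note shows. Statements on the series, on what has been measured and on what is new or still open speak of the compounds shown alone.

Measured compounds:
- compound 1, `c1cncc(N2C[C@H]3CNC[C@H]3C2)c1`: 0.12 nM
- compound 2, `c1ccc(-c2cncc(N3C[C@H]4CNC[C@H]4C3)c2)cc1`: 0.16 nM
- compound 3, `c1ccc(-c2ccc(N3C[C@H]4CNC[C@H]4C3)nc2)cc1`: only a limit, > 100000 nM

In an assay on membranes from brain for displacement of a labelled ligand from Neuronal acetylcholine receptor; alpha4/beta2 (Rattus norvegicus) (on this read-out higher numbers stand for weaker inhibition and lower numbers for stronger inhibition), compound 1 gives 0.12 nM and compound 2 gives 0.16 nM. The step of a 1.3-fold lower number from compound 2 to compound 1 (0.12 log units; within the scatter) is hydrogen in place of phenyl on an aromatic carbon. For compound 3 the value in this assay is a limit of the assay and not a number, > 100000 nM; the point the limit of > 100000 nM in this assay, at which 1 of the 3 values shown sits, marks where that limit sits. Compound 2 and compound 3 are built from the same atoms joined differently; the difference between the two cores is not broken down here.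

Compound 4, `c1ccc(N2C[C@H]3CNC[C@H]3C2)nc1`, is not yet measured in this assay. It is obtained from compound 3 by hydrogen in place of phenyl on an aromatic carbon. Going by the values given here, this is the same kind of change as the one from compound 2 to compound 1, but the place differs: in compound 2 the phenyl stands meta to a group of 8 heavy atoms, in compound 3 it stands para to a group of 8 heavy atoms.

Within the core of compound 2 the phenyl made no difference beyond the scatter, as a 1.3-fold lower number from compound 2 to compound 1 (0.12 log units; within the scatter) shows. For compound 4 the reference is the core of compound 3, whose own value is only the limit > 100000 nM, so an equally small step would leave compound 4 at or near that limit. The expected step is an at least 3.3-fold lower number from compound 3 to compound 4 (0.52 log units; beyond the scatter), resting on compound 3 having given only the limit > 100000 nM and on the phenyl having counted for little in a 1.3-fold lower number from compound 2 to compound 1 (0.12 log units; within the scatter). Compound 4 is therefore expected to give about 30000 nM in this assay, with a wide range from 2000 nM to 200000 nM, and a substantial chance that again only a limit is reported.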

Compound 4, inhibition constant: 260 nM
Compound 4: the middle estimate sits 120-fold (2.06 log units) above what was measured; measured number outside the range, below it.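

In this assay hydrogen in place of phenyl gives an at least 380-fold lower number from compound 3 to compound 4 (2.58 log units; beyond the scatter), so this change does not carry over from one core to the other with one size: the same change on two cores in this assay, a 1.3-fold lower number (0.12 log units; within the scatter) from compound 2 to compound 1 and an at least 380-fold lower number (2.58 log units; beyond the scatter) from compound 3 to compound 4, at least 280-fold (2.46 log units) apart, beyond the scatter of two such steps.

From the compounds shown here alone, compound 3 gives > 100000 nM, which is a limit of the assay and not a number, so the step has a lower end only and its true size stays unknown: the limit of > 100000 nM in this assay, at which 1 of the 4 values shown sits.

The result shows that the phenyl counts for little on the core of compound 2 and for much on the core of compound 3, but the place of the phenyl differs along with the core, so the two cannot be separated, and nothing here says how the change would run on any further core.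

The compounds shown leave open how the value moves between hydrogen and phenyl on the core of compound 4, for instance whether a methyl, a methoxy group or an amine at that place stays close to compound 4 or falls away toward compound 3. Also open, going by these compounds, is whether a carboxylic acid or a longer chain at the place of the phenyl on the core of compound 2 would pass as unnoticed as the phenyl does there.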